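The compounds below may be only part of what the source reports. "The series", "measured", "known", "first", "only" and "open" are said of these compounds alone.

Compound 1 `O=c1c(C2N=C(c3ccccc3)SS2)coc2ccc(Cl)cc12`: in a functional assay on PC-3 cells (Homo sapiens) for inhibition, read by sulforhodamine B assay, with a stated time of 48 h, tested at 100 uM (on this read-out lower numbers stand for less inhibition of growth and higher numbers for more inhibition of growth at the one concentration tested), compound 1 gives 62%.
Compound 2 `O=c1c(C2N=C(c3ccccc3)SS2)coc2cc(Cl)c(Cl)cc12`: in this assay compound 2 gives 70%.

Among the measured compounds shown here, compound 2 shows the larger of the two numbers, with compound 1 as its only neighbour, yet the gap a number 8 percentage points higher from compound 1 to compound 2 (within the scatter) lies within the scatter, so neither compound can be said to exceed the other. Compound 3 `O=c1c(C2N=C(c3ccccc3)SS2)coc2cc(Cl)ccc12` has not yet been measured in this assay. It differs from compound 2 by hydrogen in place of chloro on an aromatic carbon. For the measured compounds named here, only one measured step bears on this change, the one from compound 1 to compound 2, a number 8 percentage points higher from compound 1 to compound 2 (within the scatter), in which the number moved within the scatter. Going by the values given here, the reverse of that step is not the change at hand: compound 3 removes the chloro that compound 1 carries while keeping the one that compound 2 adds, so no measured step describes this removal directly. Among the compounds with values here, since the one chloro change seen stayed within the scatter, the expected step is a number 7 percentage points lower from compound 2 to compound 3 (within the scatter), not beyond the scatter. Compound 3 is therefore estimated at 63% in this assay, within 48% to 78%.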

Compound 3, percent growth inhibition at one concentration: 81%
The estimate for compound 3 lay 18 percentage points below the measured number, and the stated range ends below it.
By their numbers in this assay, from the lowest: compounds 1 and 2 (each within the scatter of the next); then compound 3.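

Among the compounds shown here, replacing this chloro with hydrogen, on the aromatic carbon ortho to a chloro group, gives a number 11 percentage points higher from compound 2 to compound 3 (beyond the scatter) in this assay, the first step in this small set to pass beyond the scatter; the earlier step (a number 8 percentage points higher from compound 1 to compound 2 (within the scatter)) concerned the other chloro and stayed within it. The result therefore shows that the chloro which compound 1 also carries is not required for a high number at the one concentration tested, since compound 3, which lacks it, sits above compound 2 by a modest margin, and that a chloro change on this ring need not remain within the scatter. No measurement shown gives any reason for this rise.

The compounds shown leave open how other groups would behave on this carbon, such as fluoro, methoxy or an amine, and whether any of them would match hydrogen or chloro. They also leave open how far the step carries over to a change elsewhere, for example a carboxylic acid on the phenyl ring of the shared core.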